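Aryl swap on compound 1: expected lipophilicity of compound 4

The source may report more compounds than this note shows. Statements on the series, on what has been measured and on what is new or still open speak of the compounds shown alone.

For the measured compounds named here, compound 1 `Cc1c(NCc2nnc(-c3ccncc3)o2)c(=O)n(-c2ccccc2)n1C` is the least lipophilic member of the three measured so far: in a physicochemical assay for lipophilicity, measured as octanol-water partition (on this read-out higher numbers stand for higher lipophilicity and lower numbers for lower lipophilicity), compound 1 gives 0.8, whereas compound 2 `Cc1c(NCc2nnc(-c3ccccc3Cl)o2)c(=O)n(-c2ccccc2)n1C` gives 2.72 and compound 3 `Cc1ccc(-c2nnc(CNc3c(C)n(C)n(-c4ccccc4)c3=O)o2)cc1` gives 2.48. Both measured steps away from compound 1 are large: a number 1.92 log units higher from compound 1 to compound 2 (beyond the scatter) and a number 1.68 log units higher from compound 1 to compound 3 (beyond the scatter). Between the two carbon-only aryl analogues the gap is a number 0.24 log units lower from compound 2 to compound 3 (within the scatter).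

Compound 4 `Cc1c(NCc2nnc(-c3ccc(Cl)cc3)o2)c(=O)n(-c2ccccc2)n1C` is not yet measured. It differs from compound 1 as follows: 4-chlorophenyl in place of pyridin-4-yl on an aromatic carbon. The two recorded steps bear on it directly, since each also exchanges pyridin-4-yl for a six-membered aromatic ring of carbon only, and each raised this assay by a large amount. For compound 4 a step of similar size and direction is therefore expected, a number 2.00 log units higher from compound 1 to compound 4 (beyond the scatter). For compound 4 the estimate in this assay is 2.8, with a range from 2.3 to 3.3.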

Compound 4, partition coefficient: 2.7
Estimate against measurement, compound 4: 0.10 log units above, within the range that was stated.
By their numbers in this assay, from the lowest: compound 1; then compounds 3, 4 and 2 (each within the scatter of the next).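

In this assay, 4-chlorophenyl at this position, on the aromatic carbon next to the ring oxygen, gives a large step of the same kind as the two earlier carbon-only aryl groups (a number 1.90 log units higher from compound 1 to compound 4 (beyond the scatter)). Neither the placement of the chloro nor chloro in place of methyl separates the carbon-only analogues: the comparison with the 2-chlorophenyl analogue gives (a number 0.02 log units lower from compound 2 to compound 4 (within the scatter)) and the comparison with the 4-methylphenyl analogue gives (a number 0.22 log units higher from compound 3 to compound 4 (within the scatter)), both within the scatter. At this position, the series therefore divides only into pyridin-4-yl and the three carbon-only aryl groups, and nothing measured here explains that division.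

Open, from the compounds shown here alone, is whether pyridin-3-yl would stay near compound 1 or near compound 4. Also open, going by these compounds, is whether an amine or a carboxylic acid on the phenyl ring, or a longer chain in place of the ring, would move the read-out away from compound 4.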